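Flipping One Ring Stereocentre in an Antiproliferative Series

The source may hold more compounds than are shown below. What is called first, only, known or untested is meant among the compounds shown, and "the series" means these compounds.

Compound 1 `Cc1cc(C)c(CN2CCc3c(Cl)cc([C@@H](CO)[C@@H]4CCCO4)c(Cl)c3C2=O)c(=O)[nH]1` is tested in a functional assay on KARPAS-422 cells (Homo sapiens) for antiproliferative activity, read by resazurin assay, with a stated time of 72 h (on this read-out higher numbers stand for weaker inhibition and lower numbers for stronger inhibition), where it gives 1220 nM. Among the compounds with a single number it stands lowest: compound 3 `COc1cc(C)[nH]c(=O)c1CN1CCc2c(Cl)cc([C@@H](O)C3COC3)c(Cl)c2C1=O` gives 10600 nM, a gap that lies beyond the usual scatter. Compound 2 `COC(c1cc(Cl)c2c(c1Cl)C(=O)N(Cc1c(C)cc(C)[nH]c1=O)CC2)C1CCN(C(C)=O)CC1` gives 1620 nM; 22 nM (2 entries), and these several entries, (the several entries of compound 2 in this assay, 1620 nM; 22 nM (2 entries)), spread too widely to rank it against the others. Among the compounds with values here, compound 4 `Cc1cc(C)c(CN2CCc3c(Cl)cc([C@@H](CO)[C@H]4CCCO4)c(Cl)c3C2=O)c(=O)[nH]1` has not yet been measured. the two compounds have the same atoms and bonds and differ only in configuration as drawn: 1 of 2 stereo elements differ; a stereocentre at a saturated ring carbon is drawn S in compound 1 and R in compound 4 No measured pair shows a comparable change, so the direction of this step is open; a shift either way is possible, but a step no larger than the scatter seems the most likely outcome. Compound 4 is therefore expected to give 1500 nM, within a range of 300 nM to 7000 nM, which amounts to an estimated step of a 1.2-fold higher number from compound 1 to compound 4 (0.09 log units; within the scatter).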

Compound 4, half-maximal inhibitory concentration: 535 nM
For compound 4 the middle estimate is 2.8-fold (0.45 log units) above the measured one; measured number inside the range.
By their numbers in this assay, from the lowest: compound 4; then compound 1; then compound 3.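

In this assay, the configuration at this saturated ring carbon matters on its own: going from S to R gives a 2.3-fold lower number from compound 1 to compound 4 (0.36 log units; beyond the scatter), a modest change. The earlier compounds shown here differed in several places and could not separate such an effect. The step can be assigned to this one stereocentre because nothing else changes: the fact that compounds 1 and 4 differ only in the configuration as drawn

Still open, going by these compounds, is what inverting the other stereocentre would do. Also open, on these data alone, is whether an amine or a carboxylic acid on that same ring carbon would move the number further.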